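The compounds below may be only part of what the source reports. "The series", "measured", "known", "first", "only" and "open" are said of these compounds alone.

Measured so far:
- compound 1, `O=C(O)Cc1sc(NCc2ccccc2)nc1-c1ccc(Cl)cc1`: 2300 nM
- compound 2, `NS(=O)(=O)c1ccc(-c2nc(C(c3ccc(F)cc3)c3ccc(F)cc3)sc2CC(=O)O)cc1`: > 100000 nM

Compound 1 is the only one of the two with a numerical result: in an in vitro functional assay on HEK285-7 cells for antagonist activity at prostaglandin D2 receptor 2 (Homo sapiens), read by BRET and beta-arrestin recruitment (a lower number here means a stronger inhibitor, a higher number a weaker inhibitor), compound 1 gives 2300 nM. For compound 2 the result is a limit rather than a number: in this assay compound 2 gives > 100000 nM, which places it at the limit of > 100000 nM in this assay, at which 1 of the 2 values shown sits. So compound 2 stands at the weak end of what this assay can report, and nothing closer than that is known about it.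

Compound 3, `O=C(O)Cc1sc(C(c2ccc(F)cc2)c2ccc(F)cc2)nc1-c1cc(F)nc(F)c1`, is not yet measured. It differs from compound 2 in one place: 2,6-difluoropyridin-4-yl in place of 4-sulfamoylphenyl on an aromatic carbon. The rest of the molecule, including the carboxymethyl group on the core and the large group on the other side of the ring, is unchanged.

For the measured compounds named here, no step between two measured compounds is available to show how this assay responds to a change at this position, so the direction is uncertain. Compound 2 sits at a limit, so any outcome that is a number would already mean a gain, while a repeat of the limit is also possible. The expected step from compound 2 to compound 3 is an at least 3.3-fold lower number from compound 2 to compound 3 (0.52 log units; beyond the scatter), a moderate gain. Compound 3 is thus estimated at 30000 nM in this assay, within a wide range from 3000 nM to 100000 nM.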

Compound 3, half-maximal inhibitory concentration: 110 nM
Estimate against measurement, compound 3: 270-fold (2.44 log units) above; measured number outside the range, below it.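

The group on this carbon of the shared core turns out to matter a great deal: with the rest of the molecule unchanged, putting 2,6-difluoropyridin-4-yl in place of 4-sulfamoylphenyl gives an at least 900-fold lower number from compound 2 to compound 3 (2.95 log units; beyond the scatter) in this assay. For the compounds shown here, the earlier compounds offered no step at all, so this is the first direct sign that the response to a change at this position can be large, and that a compound at the weak end of the scale can become a clearly measurable inhibitor through this one swap. The printed step is only a lower bound, and its full size cannot be stated, because compound 2 has a limit rather than a number: the limit of > 100000 nM in this assay, at which 1 of the 3 values shown sits.

The swap changes several things at once, removing the sulfamoyl group, placing a nitrogen in the six-membered ring and adding two fluorines, so the compounds shown cannot say which of these accounts for the gain. As far as these compounds go, a plain pyridin-4-yl without the fluorines, or an unsubstituted phenyl, would help to separate these parts, and how either would fare at this position remains open.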